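Swapping 4-nitrophenyl for pyridin-4-yl on a carbonyl carbon

The source may report more compounds than this note shows. Statements on the series, on what has been measured and on what is new or still open speak of the compounds shown alone.

Compound 1 `CCCCc1ccc2[nH]c(-c3ccc(OC)cc3)c(/C=N/O)c2c1` gives 212 nM
Compound 2 `CCCCc1ccc2[nH]c(-c3ccc(OC)cc3)c(/C=N/NC(=O)c3ccc([N+](=O)[O-])cc3)c2c1` gives 312 nM

Both numbers come from a functional assay on MCF7 cells (Homo sapiens) for antiproliferative activity, with a stated time of 5 days (a higher number here means a weaker inhibitor, a lower number a stronger inhibitor), and they lie within the usual scatter of each other, so the two compounds cannot be ranked. On the data so far, compound 2 stands level with compound 1.

The next compound, compound 3 `CCCCc1ccc2[nH]c(-c3ccc(OC)cc3)c(/C=N/NC(=O)c3ccncc3)c2c1` keeps the core of compound 2 and differs in one place: pyridin-4-yl in place of 4-nitrophenyl on a carbonyl carbon with everything else unchanged.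

Among the compounds with values here, no measured step yet shows what such a swap does in this assay so its size can only be judged loosely. Within the data shown here, the one guide is that compound 1 at 212 nM and compound 2 at 312 nM sit within the scatter of each other, so no step beyond the scatter is expected in either direction.

For compound 3 the estimated value is 300 nM with an expected range from 100 nM to 900 nM on the present evidence. This estimate means an expected 1.0-fold lower number from compound 2 to compound 3 (0.02 log units; within the scatter) which stays inside the scatter.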

Compound 3, half-maximal inhibitory concentration: 69 nM
The estimate for compound 3 lay 4.3-fold (0.64 log units) above the measured number; measured number below the stated range.
By their numbers in this assay, from the lowest: compound 3; then compounds 1 and 2 (each within the scatter of the next).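

In this assay, the group on this carbonyl carbon clearly matters: with everything else unchanged, pyridin-4-yl in place of 4-nitrophenyl gives a 4.5-fold lower number from compound 2 to compound 3 (0.66 log units; beyond the scatter). Replacing hydroxy on the double-bonded nitrogen with ((pyridin-4-yl)carbonyl)amino gives a 3.1-fold lower number from compound 1 to compound 3 (0.49 log units; beyond the scatter), whereas compound 2, which carries a (4-nitrophenyl)carbonyl group instead, stands level with compound 1, so adding a carbonyl-linked aromatic ring at this nitrogen does not by itself lower the number, and the outcome depends on which ring is attached. Compound 3 is the strongest inhibitor of the three, but nothing available here explains why this swap has such an effect.

The swap removes the nitro group and places a nitrogen in the ring in a single change, so these compounds leave open which of the two accounts for the step. A plain phenyl ring on the same carbonyl carbon would separate those two changes, while pyridin-3-yl and pyridin-2-yl would show whether the location of the ring nitrogen matters.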